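Half-life of an amidine series after a side-group swap

This account rests on a few compounds, and the source may have more. Where it says the series, first, only, none or still open, it means among the compounds named here.

Measured so far in an in vivo ADME assay on the whole organism (Cavia porcellus); a lower number here means that the compound disappears faster, a higher number that the compound lasts longer:
- compound 1 `CCCCCC(NC(=O)c1ccc(C(=N)N)cc1)C(C)(C)C(=O)N1CCC(CC(=O)O)CC1`: 0.517 h
- compound 2 `CC(C)(C(=O)N1CCC(CC(=O)O)CC1)C(NC(=O)c1ccc(C(=N)N)cc1)c1ccc2ccccc2c1`: 0.85 h

For the measured compounds named here, compound 2 stands at one end of the two numbers, with compound 1 as its only neighbour; the step of a 1.6-fold higher number from compound 1 to compound 2 (0.22 log units; within the scatter) is within the scatter, so the two compounds cannot be told apart by these data.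

Compound 3 `CC(C)(C(=O)N1CCC(CC(=O)O)CC1)C(NC(=O)c1ccc(C(=N)N)cc1)c1cccc(Cl)c1` differs from compound 2 at a single place: 3-chlorophenyl in place of naphthalen-2-yl on a saturated chain carbon bound to an amide-type nitrogen and a saturated chain carbon

Going by the values given here, only one measured step touches this position, the one from compound 1 to compound 2, and it stayed within the scatter despite a large change of group at the same carbon. Nothing in the two numbers suggests that this part of the molecule moves the half-life in this assay by much. Compound 3 is therefore expected to land close to compound 2, with an estimated step of a 1.2-fold lower number from compound 2 to compound 3 (0.08 log units; within the scatter), a drift that would itself be within the scatter. The half-life of compound 3 in this assay is estimated at 0.7 h, with a likely range from 0.35 h to 1.4 h.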

Compound 3, half-life: 2.5 h
The estimate for compound 3 lay 3.6-fold (0.55 log units) below the measured number; the whole stated range lies below it.
By their numbers in this assay, from the lowest: compounds 1 and 2 (each within the scatter of the next); then compound 3.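

At this saturated chain carbon, bound to an amide-type nitrogen and a saturated chain carbon, the group can change the half-life after all: in this assay the swap to 3-chlorophenyl gives a 2.9-fold higher number from compound 2 to compound 3 (0.47 log units; beyond the scatter) and, measured against the pentyl group, a 4.8-fold higher number from compound 1 to compound 3 (0.68 log units; beyond the scatter). The earlier step, a 1.6-fold higher number from compound 1 to compound 2 (0.22 log units; within the scatter), had suggested that this carbon tolerates large changes with little effect, but it now appears that pentyl and naphthalen-2-yl simply could not be told apart, while 3-chlorophenyl stands clear of both. Nothing available here explains why one aromatic ring carrying chlorine separates from the two-ring naphthalen-2-yl group in this way.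

The compounds shown leave open whether the chlorine or the single ring accounts for the step, a question that a plain phenyl group, or a fluorine in place of the chlorine, would help to settle. Also open, on these data alone, is whether a cyclohexyl group on the same carbon would stay with pentyl and naphthalen-2-yl or go with 3-chlorophenyl.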